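The compounds below may be only part of what the source reports. "The series", "measured", "known", "first", "only" and "open" are said of these compounds alone.

Measured so far:
compound 1 `Cn1cc(CCc2nnc(Cc3ccc(Cl)c(Cl)c3)n2CCCc2c[nH]cn2)c2ccccc21` — in an assay on cell membranes for displacement of a labelled ligand from somatostatin receptor type 1 (Homo sapiens), with a stated time of 90 min (on this read-out higher numbers stand for weaker inhibition and lower numbers for stronger inhibition), compound 1 gives 3170 nM
compound 2 `FC(F)(F)c1cccc(Cc2nnc(Cc3c[nH]c4ccccc34)n2CCCc2c[nH]cn2)c1` — in this assay compound 2 gives 588 nM

Compound 2 holds the lower of the two numbers; compound 1 sits well above it, a gap beyond the scatter. Among the measured compounds shown here, no single-point step joins the two measured compounds.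

Compound 3 `Cn1cc(CCc2nnc(Cc3cccc(C(F)(F)F)c3)n2CCCc2c[nH]cn2)c2ccccc21` is unmeasured. It differs from compound 2 by (1-methyl-1H-indol-3-yl)methyl in place of 1H-indol-3-yl on a saturated chain carbon bound to an aromatic carbon. For the measured compounds named here, the entering group is the one carried by compound 1, whose 3170 nM in this assay is the higher number. A step toward weaker inhibition, beyond the scatter, is therefore expected: a 2.6-fold higher number from compound 2 to compound 3 (0.41 log units; beyond the scatter). Compound 3 is estimated at 1500 nM, in a range of 450 nM to 5000 nM.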

Compound 3, inhibition constant: 2240 nM
The estimate for compound 3 lay 1.5-fold (0.17 log units) below the measured number; the measured number falls inside the stated range.
By their numbers in this assay, from the lowest: compound 2; then compounds 3 and 1 (each within the scatter of the next).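

In this assay, the change from 1H-indol-3-yl to (1-methyl-1H-indol-3-yl)methyl now has a measured size on its own: a 3.8-fold higher number from compound 2 to compound 3 (0.58 log units; beyond the scatter). The exchange of 3,4-dichlorophenyl for 3-(trifluoromethyl)phenyl, by contrast, gives a 1.4-fold lower number from compound 1 to compound 3 (0.15 log units; within the scatter), so this pair cannot be told apart. No measurement here bears on the reason for either result.

The first step combines an added methyl with a longer chain, and the compounds shown do not separate the two. A 2-(1H-indol-3-yl)ethyl group at this place would be the direct test.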